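The source may hold more compounds than are shown below. What is called first, only, known or untested is meant among the compounds shown, and "the series" means these compounds.

Measured so far:
compound 1, `O=C1NCCc2nc(C#Cc3cccc(F)c3)sc21` — 290 nM
compound 2, `COc1ccccc1C#Cc1nc2c(s1)C(=O)NCC2` — limit of > 10000 nM
compound 3, `CN1CCc2nc(C#Cc3ccccc3)sc2C1` — 34 nM

In an assay on HEK293 cells for positive allosteric modulation of metabotropic glutamate receptor 5 (Homo sapiens), read by FLIPR, with a stated time of 1 h (a higher number here means that more compound is needed for the effect, a lower number that less compound is needed), compound 3 gives 34 nM, the lower of the two numbers in the set. Compound 1 gives 290 nM, a higher number than compound 3 by a gap beyond the usual scatter. Compound 2 reaches only the limit of > 10000 nM, so no number is known for it; this is the situation described by the limit of > 10000 nM in this assay, at which 1 of the 3 values shown sits.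

Compound 4, `O=C(C1CC12CCC2)N1CCc2nc(C#Cc3ccccc3)sc2C1`, is not yet measured in this assay. It differs from compound 3 in one place: a group of 8 heavy atoms (7 carbon, 1 oxygen; one three-membered non-aromatic ring of carbon only, one four-membered non-aromatic ring of carbon only) in place of one carbon atom, on an amine nitrogen in a ring. The shared core with its phenylethynyl group and the ring amine nitrogen is kept; only the substituent on that nitrogen changes, from a methyl to an acyl group carrying a spiro arrangement of a three-membered and a four-membered carbon ring.

Within the data shown here, no step between measured compounds covers a change of this kind, so nothing in the set calibrates it. The expectation is a modest step, and compound 4 is estimated at 40 nM, within 10 nM to 200 nM. This estimate means a step of a 1.2-fold higher number from compound 3 to compound 4 (0.07 log units; within the scatter), which is expected to fall at or near the usual scatter rather than clearly beyond it.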

Compound 4, half-maximal effective concentration: 3.9 nM
Estimate against measurement, compound 4: 10-fold (1.01 log units) above; the whole stated range lies above it.
By their numbers in this assay, from the lowest: compound 4; then compound 3; then compound 1. At a limit, above all of these: compound 2.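

On the amine nitrogen in the ring, the set previously held only the methyl of compound 3, so nothing showed how far this position could be built out. In this assay, replacing that methyl with an acyl group of 8 heavy atoms, carrying a three-membered and a four-membered carbon ring, gives an 8.7-fold lower number from compound 3 to compound 4 (0.94 log units; beyond the scatter) and shows that this position admits a much larger substituent, with a carbonyl directly on the nitrogen, and that the number falls beyond the scatter rather than rising. No measurement shown bears on the reason for this step.

Among these compounds, the single step changes the carbonyl and both carbon rings together, so their shares remain unseparated; an acetyl group, a cyclopropanecarbonyl group, a benzoyl group or a benzyl group on the same nitrogen would divide the effect between the carbonyl and the ring system. Also open, going by these compounds, is whether the lower number holds when this acyl group is combined with a fluorine or methoxy group on the phenyl ring, or with a pyridine in place of that phenyl ring.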